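The source may hold more compounds than are shown below. What is called first, only, known or untested is meant among the compounds shown, and "the series" means these compounds.

Compound 3 `COc1cccc(C2(NC(=O)c3c(OC)cc(C(F)(F)F)cc3SC)CCCN(C)C2)c1` gives 110 nM in an assay on cells for inhibition of sodium- and chloride-dependent glycine transporter 1 (Homo sapiens) (a higher number here means that more compound is needed for the effect, a lower number that less compound is needed), the highest of the three numbers measured. Compound 1 `COc1cc(C(F)(F)F)cc(SC)c1C(=O)NC1(c2ccc(F)cc2)CCCN(C)C1` gives 26 nM and compound 2 `COc1cc(C(F)(F)F)cc(SC)c1C(=O)NC1(c2ccc(Cl)cc2)CCCN(C)C1` gives 28 nM, with a 1.1-fold higher number from compound 1 to compound 2 (0.03 log units; within the scatter). Two measured steps exchange the aryl group on the saturated ring and so bear on the present change: a 4.2-fold higher number from compound 1 to compound 3 (0.63 log units; beyond the scatter) and a 3.9-fold higher number from compound 2 to compound 3 (0.59 log units; beyond the scatter). Compound 4 `COc1cc(C(F)(F)F)cc(SC)c1C(=O)NC1(c2ccncc2)CCCN(C)C1` carries pyridin-4-yl in place of 3-methoxyphenyl on a saturated ring carbon. Among the measured compounds shown here, no measured step introduces a pyridinyl ring, so its direction is uncertain; because compound 3 sits at the high end by a 4.2-fold higher number from compound 1 to compound 3 (0.63 log units; beyond the scatter), a modest step back toward the other two numbers seems about as likely as no step beyond the scatter. Compound 4 is therefore expected at 80 nM, within 30 nM to 250 nM, which corresponds to an expected 1.4-fold lower number from compound 3 to compound 4 (0.14 log units; within the scatter).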

Compound 4, half-maximal effective concentration: 60 nM
Compound 4: the middle estimate sits 1.3-fold (0.12 log units) above what was measured; the range from low to high includes it.
By their numbers in this assay, from the lowest: compounds 1 and 2 (each within the scatter of the next); then compounds 4 and 3 (each within the scatter of the next).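

At this saturated ring carbon of the core, this assay accepts a six-membered aromatic ring with a hetero atom in place of one of carbon only, with pyridin-4-yl and 3-methoxyphenyl staying within the scatter (a 1.8-fold lower number from compound 3 to compound 4 (0.26 log units; within the scatter)). Compared with the halogen-bearing phenyl groups, pyridin-4-yl gives modest steps up (a 2.1-fold higher number from compound 2 to compound 4 (0.33 log units; beyond the scatter); a 2.3-fold higher number from compound 1 to compound 4 (0.36 log units; beyond the scatter)), as 3-methoxyphenyl did. Nothing given here explains these steps. The compounds shown leave open how unsubstituted phenyl or pyridin-3-yl would compare at this carbon. The role of the ring nitrogen therefore cannot be separated from the loss of the halogen.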